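Bromo for Isobutoxy: Cytotoxicity on Human Skin Cells

This account rests on a few compounds, and the source may have more. Where it says the series, first, only, none or still open, it means among the compounds named here.

Compound 1 `CCOC(=O)c1c(-c2cccc(OC)c2)[nH]c2cc(OC)ccc2c1=O`: > 21500 nM, a limit of the assay.
Compound 2 `CCOC(=O)c1c(-c2cccc(OCC(C)C)c2)[nH]c2cc(OC)ccc2c1=O`: > 21500 nM, a limit of the assay.

In an ADME assay on BJ cells (Homo sapiens) for cytotoxicity, read by luminescence, with a stated time of 72 h (on this read-out lower numbers stand for an effect already at smaller amounts and higher numbers for an effect only at larger amounts of compound), neither compound gives a number. Compound 2 sits at the limit of > 21500 nM in this assay, at which 2 of the 2 values shown sit. Within the data shown here, the one measured step, a step that the two limits leave unreadable from compound 1 to compound 2, cannot be read because of the limit of > 21500 nM in this assay, at which 2 of the 2 values shown sit. Compound 3 `CCOC(=O)c1c(-c2cccc(Br)c2)[nH]c2cc(OC)ccc2c1=O` differs from compound 2 by bromo in place of isobutoxy on an aromatic carbon. No readable step bears on this change, so no shift beyond the scatter is expected, and the step from compound 2 to compound 3 is estimated as a step that the limit leaves unreadable from compound 2 to compound 3. Compound 3 is expected near 25000 nM, between 8000 nM and 80000 nM.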

Compound 3, half-maximal effective concentration: > 21500 nM
Compound 3: no number, only a limit; the forecaster's own chance of this, stated with the estimate: 70%; the middle value does not contradict the limit.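

No step among compound 1, compound 2 and compound 3 can be read, because each value is only a limit of the assay: the limit of > 21500 nM in this assay, at which 3 of the 3 values shown sit.

The compounds shown leave open whether methoxy, isobutoxy and bromo differ at all in this assay.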